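The source may report more compounds than this note shows. Statements on the series, on what has been measured and on what is new or still open speak of the compounds shown alone.

Working notes on the series.

Compound 3 `ClCc1ccccc1Cn1cnc2nc(Cl)nc(Cl)c21` and compound 2 `ClCc1ccccc1Cn1cnc2ncnc(Cl)c21` differ in one place: hydrogen in place of chloro on an aromatic carbon. In a functional assay on UACC-257 cells (Homo sapiens) for cytotoxicity, read by sulforhodamine B assay, with a stated time of 48 h (on this read-out higher numbers stand for lower toxicity in this test and lower numbers for higher toxicity in this test), compound 3 gives 8700 nM, while compound 2 gives 61700 nM; the step is a 7.1-fold higher number from compound 3 to compound 2 (0.85 log units; beyond the scatter), a shift toward lower toxicity in this test.

Compound 1 `ClCc1ccc(Cn2cnc3nc(Cl)nc(Cl)c32)cc1` gives 34700 nM in this assay. The difference between the core of compound 1 and the core of compound 3 is not broken down here; their values show compound 1 at a higher number than compound 3, beyond the scatter. Compound 1 and compound 2 lie within the scatter of each other, so no order is read between them.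

Compound 4 `ClCc1ccc(Cn2cnc3ncnc(Cl)c32)cc1` is not yet measured. It differs from compound 1 by hydrogen in place of chloro on an aromatic carbon, which is the same change, at the same place, as that made from compound 3 to compound 2. Among the compounds with values here, the step is expected to be a 5.8-fold higher number from compound 1 to compound 4 (0.76 log units; beyond the scatter) in this assay, resting on the single earlier step of a 7.1-fold higher number from compound 3 to compound 2 (0.85 log units; beyond the scatter). Compound 4 is thus expected to give about 200000 nM, with a range from 80000 nM to 500000 nM, pending measurement.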

Compound 4, concentration lethal to 50% of the cells: 7760 nM
Beside the measured number, compound 4's estimate is 26-fold (1.41 log units) above it; measured number outside the range, below it.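

In this assay, hydrogen in place of chloro on the aromatic carbon between two ring nitrogen atoms gives a 4.5-fold lower number from compound 1 to compound 4 (0.65 log units; beyond the scatter), a shift toward higher toxicity in this test. Within the data shown here, the change therefore does not carry over from one core to the other in these compounds, since its direction reverses and the gap between the two steps is beyond the scatter: the same change on two cores in this assay, a 7.1-fold higher number (0.85 log units; beyond the scatter) from compound 3 to compound 2 and a 4.5-fold lower number (0.65 log units; beyond the scatter) from compound 1 to compound 4, 32-fold (1.50 log units) apart, beyond the scatter of two such steps With only one pair on each core, this does not show what in the cores sets the direction, nor whether a further core would follow either pair.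

As far as these compounds go, only hydrogen and chloro appear at this place, so it remains open whether an amine, a methoxy group or a longer chain there would also behave differently on the two cores. Also open, from the compounds shown here alone, is how either core would respond if a hydroxymethyl group stood in place of the chloromethyl group present in all four compounds.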